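Swapping a fluoropyrazole for a fused bicyclic ring

The source may report more compounds than this note shows. Statements on the series, on what has been measured and on what is new or still open speak of the compounds shown alone.

In a physicochemical assay for lipophilicity, using the shake flask method, at pH 7.4 (on this read-out higher numbers stand for higher lipophilicity and lower numbers for lower lipophilicity), three compounds sharing one core have been measured. Compound 1, `CCCC(Oc1ccc(-n2cc(F)cn2)cc1)c1ccc(C(=O)NCCC(=O)O)cc1`, gives 2 and holds the second highest place among the three. Compound 2, `CCCC(Oc1ccc(-n2cc(C(F)(F)F)cn2)nc1)c1ccc(C(=O)NCCC(=O)O)cc1`, gives 2.6 in this assay, the highest of the set and a gap above compound 1 that lies beyond the usual scatter. Compound 3, `CCCC(Oc1cnc(-n2cc(C(F)(F)F)cn2)nc1)c1ccc(C(=O)NCCC(=O)O)cc1`, gives 1.5 in this assay, a gap below compound 1 that is likewise beyond the scatter. Compound 1 thus sits between the other two, separated from each by more than repeat measurements would account for.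

Compound 4, `CCCC(Oc1ccc(-n2cc3c(n2)CCCC3)cc1)c1ccc(C(=O)NCCC(=O)O)cc1`, has not yet been measured in this assay. It differs from compound 1 at one place, on an aromatic carbon of a six-membered aromatic ring of carbon only, para to a large group: a group of 9 heavy atoms (7 carbon, 2 nitrogen; one five-membered aromatic ring with 2 hetero atoms, one six-membered non-aromatic ring of carbon only) in place of a group of 6 heavy atoms (3 carbon, 2 nitrogen, 1 fluorine; one five-membered aromatic ring with 2 hetero atoms), on an aromatic carbon. The 4-fluoro-1H-pyrazol-1-yl group leaves and a larger group with an added six-membered non-aromatic ring of carbon only enters.

Among the measured compounds shown here, no measured pair in the set shows this change, so the account rests on expectation alone. The step from compound 1 to compound 4 is expected to be upward and beyond the scatter, about a number 0.90 log units higher from compound 1 to compound 4 (beyond the scatter). Compound 4 is therefore estimated at 2.9 in this assay, within a range from 2.3 to 3.5.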

Compound 4, distribution coefficient: 2.7
For compound 4 the middle estimate is 0.20 log units above the measured one; the range from low to high includes it.
By their numbers in this assay, from the lowest: compound 3; then compound 1; then compounds 2 and 4 (each within the scatter of the next).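

Among the compounds shown here, for the first time the set holds a pair of compounds that differ in one place, so this position, on an aromatic carbon of a six-membered aromatic ring of carbon only, para to a large group, can be read directly. In this assay the result is a number 0.70 log units higher from compound 1 to compound 4 (beyond the scatter) when 4-fluoro-1H-pyrazol-1-yl gives way to the larger group of 9 heavy atoms with its added six-membered non-aromatic ring of carbon only. The two groups have equal counts of hydrogen-bond donors and acceptors and no net charge, so the read-out moves here with no change in those counts, and nothing measured in the set accounts for the size of the step.

The single step joins two changes, the loss of the fluorine and the gain of the added ring, and the compounds shown do not separate them, as a pyrazole carrying only a methyl group in place of the fluorine might. Nor do they show how the read-out would respond to a hydroxyl group or an amine on the added ring, or whether the step would hold on another core.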